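This account rests on a few compounds, and the source may have more. Where it says the series, first, only, none or still open, it means among the compounds named here.

Measured so far:
Compound 1 `O=C(Nc1ccccc1)c1cnc(NCc2c(F)ccc3c2CCO3)n2cnnc12`: < 1000 nM
Compound 2 `Cc1nc(CN(C)C)ccc1-c1cnc(NCc2c(F)ccc3c2CCO3)c2cn[nH]c(=O)c12`: > 1000000 nM

In a physicochemical assay for solubility, read by LC-MS, in phosphate buffer, with a stated time of 24 h, at pH 7.4 (a higher number here means a more soluble compound, a lower number a less soluble compound), compound 1 gives < 1000 nM, which is a limit of the assay rather than a number. In this assay compound 2 gives > 1000000 nM, again a limit and not a number. Compound 1 therefore stands at the lower edge of what can be read (the limit of < 1000 nM in this assay, at which 1 of the 2 values shown sits). For the measured compounds named here, the only other value sits at the upper edge (the limit of > 1000000 nM in this assay, at which 1 of the 2 values shown sits). Going by the values given here, no pair of measured compounds differs in a single place, so no measured step exists to lean on. Compound 3 `O=C(Nc1cnc(NCc2c(F)ccc3c2CCO3)n2cnnc12)c1ccccc1` differs from compound 1 in one place: benzamido in place of phenylcarbamoyl on an aromatic carbon. The two hold the same atoms, joined differently at that one carbon. With nothing measured to guide it, the step expected in this assay is an at least 1.5-fold higher number from compound 1 to compound 3 (0.17 log units; that floor lies within the scatter), small and in no set direction beyond the scatter. Compound 3 is expected to give 1500 nM, within 300 nM to 8000 nM, quite possibly reported again only as a limit.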

Compound 3, solubility: 2000 nM
For compound 3 the middle estimate is 1.3-fold (0.12 log units) below the measured one, and the stated range covers the measured number.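

In this assay, benzamido in place of phenylcarbamoyl on this aromatic carbon, with the same atoms simply joined differently, gives an at least 2.0-fold higher number from compound 1 to compound 3 (0.30 log units; that floor lies within the scatter). For the compounds shown here, compound 3 gives 2000 nM, the first value in this set that is a number and not a limit of the assay. The change may be small or large, and its true size cannot be read because compound 1 gives only a limit: the limit of < 1000 nM in this assay, at which 1 of the 3 values shown sits.

Going by these compounds, whether a different group on this aromatic carbon, such as an amine or a carboxylic acid, would move the number beyond the usual scatter remains open. So does the effect of a longer chain in place of benzamido, which would show how far this position tolerates change in the read-out.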